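A Smaller Aryl Group and Cytotoxicity in Mouse Cells

The source may report more compounds than this note shows. Statements on the series, on what has been measured and on what is new or still open speak of the compounds shown alone.

Compound 1, `FC(F)(F)Oc1ccc(Nc2cc(-c3cccc4[nH]ccc34)ncn2)cc1`, gives 3790 nM. Compound 2, `CNC(=O)c1cccc(-c2cc(Nc3ccc(OC(F)(F)F)cc3)ncn2)c1`, sits at the assay limit > 10000 nM. Compound 3, `OCCn1ncc2c(Nc3ccc(OC(F)(F)F)cc3)ncnc21`, sits at the assay limit > 10000 nM.

Among the compounds with values here, in an ADME assay on BaF3 cells (Mus musculus) for cytotoxicity (on this read-out higher numbers stand for an effect only at larger amounts of compound and lower numbers for an effect already at smaller amounts), compound 1 is the only compound with an actual number; the other two values are the limit of > 10000 nM in this assay, at which 2 of the 3 values shown sit. Compound 4, `FC(F)(F)Oc1ccc(Nc2cc(-c3ccncc3)ncn2)cc1`, differs from compound 1 by pyridin-4-yl in place of 1H-indol-4-yl on an aromatic carbon. Within the data shown here, no measured pair shares this change, so its size is unknown; a small shift toward an effect only at larger amounts, near the edge of the usual scatter, seems the most likely outcome. Compound 4 is therefore expected at 6000 nM, with a range from 2500 nM to 15000 nM. This expectation amounts to a step of a 1.6-fold higher number from compound 1 to compound 4 (0.20 log units; within the scatter).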

Compound 4, half-maximal effective concentration: > 10000 nM
Compound 4: no number, only a limit (the forecaster's own chance of this, stated with the estimate: 40%); at least 1.6-fold (0.22 log units) between middle value and limit.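

At this aromatic carbon, replacing 1H-indol-4-yl with pyridin-4-yl gives an at least 2.6-fold higher number from compound 1 to compound 4 (0.42 log units; beyond the scatter) in this assay. Compound 4 gives > 10000 nM as a limit of the assay and not a number. As far as these compounds go, the true size of the step stays unknown because the read-out ends at a limit: the limit of > 10000 nM in this assay, at which 3 of the 4 values shown sit.

The compounds shown leave open whether the second ring of 1H-indol-4-yl or its hydrogen-bond donor goes with the lower number. From the compounds shown here alone, how a phenyl or aminophenyl group on the same carbon would read also remains open.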